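Dialkyl Substitution on the Acid-Bearing Carbon: Working Notes

This account rests on a few compounds, and the source may have more. Where it says the series, first, only, none or still open, it means among the compounds named here.

Measured compounds:
- compound 1, `CC(C)(CC(=O)Nc1cccc(OCc2ccc3ccc(F)cc3n2)c1)C(=O)O`; in a functional assay on ileum (Cavia porcellus) for antagonist activity at cysteinyl leukotriene receptor (Homo sapiens) (on this read-out higher numbers stand for weaker inhibition and lower numbers for stronger inhibition), compound 1 gives 1.4 nM
- compound 2, `CCC(C)(CC(=O)Nc1cccc(OCc2ccc3ccc(F)cc3n2)c1)C(=O)O`; in this assay compound 2 gives 6.4 nM

Within the data shown here, compound 2 stands at the higher of the two numbers measured so far; its only neighbour is compound 1, and the step between them is a 4.6-fold higher number from compound 1 to compound 2 (0.66 log units; beyond the scatter), brought about by methyl in place of hydrogen on a saturated chain carbon, two bonds along the chain from a carbonyl carbon.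

Compound 3, `CCCC(CCC)(CC(=O)Nc1cccc(OCc2ccc3ccc(F)cc3n2)c1)C(=O)O`, is not yet measured. Relative to compound 2 the change is 1-carboxy-1-propylbutyl in place of 1-carboxy-1-methylpropyl on a saturated chain carbon bound to a carbonyl carbon. Among the measured compounds shown here, both arms of the saturated carbon are lengthened at once, so the change goes further in the same direction as the one step available. For the measured compounds named here, that step, a 4.6-fold higher number from compound 1 to compound 2 (0.66 log units; beyond the scatter), was a modest loss of inhibition, and only one such step exists, so the extrapolation rests on a single observation.

The expectation for compound 3 is a further rise in the number, of roughly a 4.7-fold higher number from compound 2 to compound 3 (0.67 log units; beyond the scatter), in this assay. Compound 3 is estimated at 30 nM, with a range from 8 nM to 120 nM.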

Compound 3, half-maximal inhibitory concentration: 2 nM
For compound 3 the middle estimate is 15-fold (1.18 log units) above the measured one, outside the stated range (below it).
By their numbers in this assay, from the lowest: compounds 1 and 3 (each within the scatter of the next); then compound 2.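

In this assay, the number at the saturated chain carbon bound to a carbonyl carbon does not rise steadily as the groups there lengthen: 1-carboxy-1-propylbutyl in place of 1-carboxy-1-methylpropyl gives a 3.2-fold lower number from compound 2 to compound 3 (0.51 log units; beyond the scatter), which runs against the direction of a 4.6-fold higher number from compound 1 to compound 2 (0.66 log units; beyond the scatter). The two ends of the series cannot be told apart, with a 1.4-fold higher number from compound 1 to compound 3 (0.15 log units; within the scatter), so the loss seen with 1-carboxy-1-methylpropyl does not carry over to the longer 1-carboxy-1-propylbutyl, and compound 2 alone stands beyond the scatter from both of the others. Nothing available accounts for this turn in the numbers.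

The three compounds leave open whether the shared feature of compound 1 and compound 3, two identical alkyl groups on the carbon bearing the acid, is what separates them from compound 2, or whether compound 2 is an isolated case. 1-carboxy-1-ethylpropyl, with an ethyl group on each side, and a cyclopentane ring closing the two groups on that carbon would each put this reading to the test, and butyl chains in place of the propyl chains would show how far the lengthening can go.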